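Compound 3: replacing the benzyl group, clearance estimate

This account rests on a few compounds, and the source may have more. Where it says the series, first, only, none or still open, it means among the compounds named here.

Measured in an in vitro ADME assay on microsomes from liver (Homo sapiens) for metabolic stability, using NADPH; a higher number here means faster removal of the compound, a lower number slower removal:
Compound 1 `COc1ccc(OC(F)(F)F)cc1Cn1c(C(=O)NCC(C)(C)CO)cc2cc(C#N)ccc21`: 69 mL.min-1.g-1
Compound 2 `COc1ccc(Br)cc1Cn1c(C(=O)NCC(C)(C)CO)cc2cc(C#N)ccc21`: 104 mL.min-1.g-1

Among the measured compounds shown here, compound 2 gives 104 mL.min-1.g-1, within the scatter of compound 1 at 69 mL.min-1.g-1, the only other measured compound. Compound 3 `CCCOc1cccc(Cn2c(C(=O)NCC(C)(C)CO)cc3cc(C#N)ccc32)c1` is next, with 3-propoxyphenyl in place of 5-bromo-2-methoxyphenyl on a saturated chain carbon bound to an aromatic nitrogen. For the measured compounds named here, the only measured step is a 1.5-fold higher number from compound 1 to compound 2 (0.18 log units; within the scatter), with bromo in place of trifluoromethoxy on an aromatic carbon. Going by the values given here, that step exchanges one substituent, whereas this change replaces the whole group, and no measured step involves 3-propoxyphenyl, so it bears only loosely. No step beyond the scatter is expected in this assay, in either direction, but the data give weak support. The estimate for compound 3 is 120 mL.min-1.g-1, with an expected range of 60 mL.min-1.g-1 to 240 mL.min-1.g-1. This estimate means a 1.2-fold higher number from compound 2 to compound 3 (0.06 log units; within the scatter).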

Compound 3, intrinsic clearance in microsomes: 156 mL.min-1.g-1
Compound 3: the middle estimate sits 1.3-fold (0.11 log units) below what was measured, and the stated range covers the measured number.
By their numbers in this assay, from the lowest: compounds 1, 2 and 3 (each within the scatter of the next, the first and the last beyond it).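

In this assay, exchanging the whole aryl group on a saturated chain carbon bound to an aromatic nitrogen, 3-propoxyphenyl in place of 5-bromo-2-methoxyphenyl, gives a 1.5-fold higher number from compound 2 to compound 3 (0.18 log units; within the scatter). The position therefore now has a measured change of the entire group, not just of one substituent, and that change also stays inside the scatter. The two ends of the set do separate, however: compound 1 gives 69 mL.min-1.g-1 and compound 3 gives 156 mL.min-1.g-1, a gap beyond the scatter even though each neighbouring pair lies within it. Nothing available gives a reason for this result.

Still open, going by these compounds, is how this assay responds to a pyridine in place of the phenyl ring, or to an amine or a carboxylic acid on that ring. A longer chain than propoxy is equally unresolved.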